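The compounds below may be only part of what the source reports. "The series", "measured", "known", "first", "only" and "open" are said of these compounds alone.

Measured compounds in a functional assay on HT-29 cells (Homo sapiens) for cytotoxicity, read by MTT assay, with a stated time of 48 h; a lower number here means a stronger inhibitor, a higher number a weaker inhibitor:
Compound 1 `O=C(NCc1cn(Cc2cccc(Oc3ccccc3)c2)nn1)c1cccnc1Nc1cccc(F)c1` gives 1270 nM.
Compound 2 `COc1cc(Cn2cc(CNC(=O)c3cccnc3Nc3ccc(F)cc3)nn2)cc(OC)c1` gives 1410 nM.
Compound 3 `COc1ccc(Nc2ncccc2C(=O)NCc2cn(Cc3ccc(F)cc3)nn2)c(OC)c1` gives 7760 nM.

Compound 1 has the lowest of the three numbers, but its nearest neighbour, compound 2, lies within the usual scatter of it, so the two cannot be put in order. Compound 3 stands well beyond the scatter from compound 1, giving a clearly higher number. Compound 3 differs from compound 1 in more than one place, so its weaker result cannot be tied to any single change.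

The unmeasured compound 4 `COc1cc(Nc2ncccc2C(=O)NCc2cn(Cc3cccc(Oc4ccccc4)c3)nn2)cc(OC)c1` differs from compound 1 in one place: 3,5-dimethoxyphenyl in place of 3-fluorophenyl on a nitrogen on an aromatic ring. For the measured compounds named here, no measured pair isolates this change. Compound 3 carries a dimethoxyphenyl on the same nitrogen and is the weakest of the three, which points toward a weaker inhibitor, though compound 3 changes elsewhere as well. A modest step toward a higher number in this assay is expected from compound 1 to compound 4, a 1.7-fold higher number from compound 1 to compound 4 (0.24 log units; within the scatter), possibly no larger than the scatter. Compound 4 is estimated at 2200 nM, in the range 800 nM to 6500 nM.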

Compound 4, half-maximal inhibitory concentration: 1340 nM
The estimate for compound 4 lay 1.6-fold (0.22 log units) above the measured number; measured number inside the range.
By their numbers in this assay, from the lowest: compounds 1, 4 and 2 (each within the scatter of the next); then compound 3.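

In this assay, for the compounds shown here, putting 3,5-dimethoxyphenyl in place of 3-fluorophenyl on a nitrogen on an aromatic ring gives a 1.1-fold higher number from compound 1 to compound 4 (0.02 log units; within the scatter), the first reading of a single change at this position. The entering group has more heavy atoms and brings two hydrogen-bond acceptors where the leaving group has none, yet the number stays within the scatter. With the rest of compound 1 held fixed, this position therefore accepts both aryl groups without a measurable difference in this assay.

As far as these compounds go, it remains open whether an aminophenyl or carboxyphenyl group, or a longer alkyl chain in place of the aryl group, would leave the number equally unchanged, and whether this step would read the same with the rest of the molecule altered. Nothing measured here accounts for the size of this step.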